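Swapping the Side-Chain Ether for an Amine on the Core

A few compounds are considered here, and "the series" means these few. Any claim that something is new, unique, unknown or untested is made for them only; others in the source may bear on it.

Compound 1 `C[n+]1ccn(CCOCCF)c1/C=N/O` is the more polar of the two measured compounds. In a physicochemical assay for lipophilicity (a higher number here means a more lipophilic compound, a lower number a more polar compound), compound 1 gives -2.62, while compound 2 `C[n+]1ccn(COCCCCCl)c1/C=N/O` gives -1.47 in this assay, a number that lies beyond the scatter above compound 1. Going by the values given here, no step between measured compounds has been worked out, so the account rests on these two values alone. Compound 3 `CN(C)CCn1cc[n+](C)c1/C=N/O` differs from compound 1 in one place, (dimethylamino in place of 2-fluoroethoxy on a saturated chain carbon, two bonds along the chain from an aromatic nitrogen). For this change the author expects a modest step downward in this assay, reading a number 0.58 log units lower from compound 1 to compound 3 (beyond the scatter), starting from the value that compound 1 gives, -2.62. Compound 3 is therefore estimated at -3.2 in this assay, within a range from -4 to -2.4.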

Compound 3, distribution coefficient: -3.06
Compound 3: middle estimate off by 0.14 log units, on the low side; the measured number falls inside the stated range.
By their numbers in this assay, from the lowest: compound 3; then compound 1; then compound 2.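

Compound 3 gives the first step measured at this position, on a saturated chain carbon, two bonds along the chain from an aromatic nitrogen. In this assay, going by these compounds alone, the exchange of 2-fluoroethoxy for dimethylamino reads a number 0.44 log units lower from compound 1 to compound 3 (beyond the scatter) and so stands as a modest change beyond the scatter, where the earlier compounds offered two values with no single-place step to link them. No measurement on hand accounts for the size or direction of this step.

On these data alone, whether another amine at this position, such as pyrrolidine or morpholine, would give a step of similar size remains open, as does the effect of a longer chain carrying the dimethylamino group. How a carboxylic acid in the same place would read in this assay against compound 1 is also unsettled.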